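Adding a Chlorine to a Weakly Cytotoxic Imine Series

The source may report more compounds than this note shows. Statements on the series, on what has been measured and on what is new or still open speak of the compounds shown alone.

Measured compounds, each in a functional assay on DLD-1 cells (Homo sapiens) for cytotoxicity, read by MTT assay, with a stated time of 72 h; on this read-out lower numbers stand for stronger inhibition and higher numbers for weaker inhibition:
- compound 1, `CCOc1cccc(/C=N/c2c(C)n(C)n(-c3ccccc3)c2=O)c1`: 724000000 nM
- compound 2, `COc1ccccc1/C=N/c1c(C)n(C)n(-c2ccccc2)c1=O`: 933000000 nM
- compound 3, `Cc1c(/N=C/c2ccccc2)c(=O)n(-c2ccccc2)n1C`: 933000000 nM

All three numbers are very high, so none of these compounds is more than marginally cytotoxic in this assay. Compound 3 carries no substituent on its six-membered aromatic ring of carbon only; it stands level with compound 2 and, together with it, gives the highest number of the three, while compound 1 lies only a little lower and still within the scatter.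

Compound 4, `Cc1c(/N=C/c2cccc(Cl)c2)c(=O)n(-c2ccccc2)n1C`, differs from compound 3 by chloro in place of hydrogen on an aromatic carbon. The two measured steps that bear on this, a 1.3-fold higher number from compound 1 to compound 3 (0.11 log units; within the scatter) and no change at the digits printed from compound 2 to compound 3 (within the scatter), both concern removing a group from the same ring and both stayed within the scatter. A chloro group is a different kind of substituent, and no measured step involves it, so the evidence is indirect; on what is shown, no change beyond the scatter is expected. Compound 4 is therefore estimated at 900000000 nM, with a plausible range of 350000000 nM to 2300000000 nM, corresponding to an expected step of a 1.0-fold lower number from compound 3 to compound 4 (0.02 log units; within the scatter).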

Compound 4, half-maximal inhibitory concentration: 724000000 nM
For compound 4 the middle estimate is 1.2-fold (0.09 log units) above the measured one; the range from low to high includes it.
By their numbers in this assay, from the lowest: compounds 1, 4, 2 and 3 (each within the scatter of the next).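

In this assay, chloro in place of hydrogen gives a 1.3-fold lower number from compound 3 to compound 4 (0.11 log units; within the scatter), so this first chlorine on the six-membered aromatic ring of carbon only does not move the number beyond the scatter. The comparisons with the two compounds bearing oxygen-linked groups agree: a 1.3-fold lower number from compound 2 to compound 4 (0.11 log units; within the scatter) and no change at the digits printed from compound 1 to compound 4 (within the scatter) are also within the scatter, so compound 4 cannot be told apart from compound 1, compound 2 or compound 3, and all four numbers remain very high. No supporting measurement is available to explain this flat result.

Going by these compounds, whether an amine or a carboxylic acid on this ring would move the number beyond the scatter remains open. So does whether bromine in place of chlorine, or a longer chain in place of ethoxy, would leave it unchanged.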